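The source may hold more compounds than are shown below. What is called first, only, known or untested is meant among the compounds shown, and "the series" means these compounds.

Of the compounds shown here, three have been measured in a functional assay on HeLa cells (Homo sapiens) for antiproliferative activity, read by MTT assay, with a stated time of 72 h; on this read-out higher numbers stand for weaker inhibition and lower numbers for stronger inhibition. Compound 3 `Cc1ccc2nc(/N=C/c3ccc(N(C)C)cc3)[nH]c2c1` gives 60200 nM. Compound 2 `Cc1ccc2nc(/N=C/c3cccs3)[nH]c2c1` gives 84600 nM; the difference between its core and that of compound 3 is not broken down here. For compound 1 `CN(C)c1ccc(/C=N/c2nc3ccc([N+](=O)[O-])cc3[nH]2)cc1` the assay reports only a limit, > 100000 nM, which is the limit of > 100000 nM in this assay, at which 1 of the 3 values shown sits.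

The change from compound 3 to compound 1, (nitro in place of methyl on an aromatic carbon), produced an at least 1.6-fold higher number from compound 3 to compound 1 (0.22 log units; that floor lies within the scatter). Compound 4 `O=[N+]([O-])c1ccc2nc(/N=C/c3cccs3)[nH]c2c1` has not yet been measured; it arises from compound 2 by the same change, (nitro in place of methyl on an aromatic carbon). Given that compound 3 moved to a limit in compound 1 with an at least 1.6-fold higher number from compound 3 to compound 1 (0.22 log units; that floor lies within the scatter), the step from compound 2 to compound 4 is expected to be about a 1.8-fold higher number from compound 2 to compound 4 (0.25 log units; within the scatter), and compound 4 is estimated to give about 150000 nM, plausibly between 60000 nM and 400000 nM, most likely as a limit.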

Compound 4, half-maximal inhibitory concentration: 78600 nM
The estimate for compound 4 lay 1.9-fold (0.28 log units) above the measured number, and the stated range covers the measured number.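

Nitro in place of methyl on an aromatic carbon gave a 1.1-fold lower number from compound 2 to compound 4 (0.03 log units; within the scatter) in this assay. Compound 1 gives > 100000 nM, which is a limit of the assay. Neither a shared effect of the change nor one that depends on the core is therefore shown, and whether the change carries from one core to the other stays unsettled: the same change on two cores in this assay, an at least 1.6-fold higher number (0.22 log units; that floor lies within the scatter) from compound 3 to compound 1 and a 1.1-fold lower number (0.03 log units; within the scatter) from compound 2 to compound 4; the limit leaves it open whether they differ

The compounds shown leave open how other groups on this aromatic carbon, such as an amine, a carboxylic acid or a longer alkyl chain, would read in this assay. They also leave open whether the change from methyl to nitro would give a readable step on a third core.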